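A few compounds are considered here, and "the series" means these few. Any claim that something is new, unique, unknown or untested is made for them only; others in the source may bear on it.

- Compound 1 `COc1ccc(S(=O)(=O)N2CCc3cccc(-c4ccc(F)cc4)c32)cc1`: 79 nM
- Compound 2 `COc1ccc(S(=O)(=O)N2CCc3cccc(-c4ccccc4)c32)cc1`: 117 nM

In a functional assay on MKN-45 cells (Homo sapiens) for inhibition, with a stated time of 72 h (on this read-out higher numbers stand for weaker inhibition and lower numbers for stronger inhibition), compound 2 gives 117 nM, which is within the usual scatter of the value for compound 1. Compound 3 `COc1ccc(S(=O)(=O)N2CCc3cccc(-c4cccs4)c32)cc1` carries a new ring: thiophen-2-yl in place of phenyl on an aromatic carbon. In words, thiophen-2-yl stands in place of phenyl on an aromatic carbon. Within the data shown here, the only measured step, a 1.5-fold higher number from compound 1 to compound 2 (0.17 log units; within the scatter), lies within the scatter, but it swaps hydrogen for fluoro and not one ring for another, so it offers only weak guidance. No shift beyond the scatter is therefore expected in this assay, in either direction. The estimated step is a 1.1-fold lower number from compound 2 to compound 3 (0.03 log units; within the scatter). For compound 3, the expected value is 110 nM, with an estimated range of 40 nM to 300 nM.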

Compound 3, half-maximal inhibitory concentration: 165 nM
Compound 3: middle estimate off by 1.5-fold (0.18 log units), on the low side; low and high end bracket the measured number.
By their numbers in this assay, from the lowest: compounds 1, 2 and 3 (each within the scatter of the next, the first and the last beyond it).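

In this assay, replacing the six-membered phenyl with the five-membered thiophen-2-yl on this aromatic carbon gives a 1.4-fold higher number from compound 2 to compound 3 (0.15 log units; within the scatter), so this ring exchange is tolerated in the data shown. Among these compounds, replacing 4-fluorophenyl with thiophen-2-yl gives a 2.1-fold higher number from compound 1 to compound 3 (0.32 log units; beyond the scatter), the first step here to pass the scatter, though only modestly. No evidence is available to explain these numbers. From the compounds shown here alone, it remains open how a pyridin-3-yl ring, or a phenyl ring carrying an amine or a carboxylic acid, would read out at this position.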